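Alkoxy chain extension on the biaryl tail

The compounds below may be only part of what the source reports. "The series", "measured", "known", "first", "only" and "open" are said of these compounds alone.

Compound 1 `CCCOc1ccc(C)c(-c2cccc(COc3ccc(OCC(=O)O)c(F)c3)c2)c1` gives 610 nM in a functional assay on CHO cells for agonist activity at Free fatty acid receptor 1 (Homo sapiens), read by FLIPR and calcium flux; a lower number here means that less compound is needed, a higher number that more compound is needed for the effect. Compound 2 `Cc1ccc(OCC(C)C)cc1-c1cccc(COc2ccc(OCC(=O)O)c(F)c2)c1` gives 1450 nM in this assay; the step of a 2.4-fold higher number from compound 1 to compound 2 (0.38 log units; beyond the scatter) goes with methyl in place of hydrogen on a saturated chain carbon bound to two saturated chain carbons. Compound 3 `COc1ccc(-c2cccc(COc3ccc(OCC(=O)O)c(F)c3)c2)cc1` gives 170 nM in this assay, the lowest of the three numbers. The difference between the core of compound 3 and the core of compound 1 is not broken down here.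

Compound 4 `CCOc1ccc(-c2cccc(COc3ccc(OCC(=O)O)c(F)c3)c2)cc1` is not yet measured. It differs from compound 3 by methyl in place of hydrogen on a saturated chain carbon bound to an oxygen on an aromatic ring. For the measured compounds named here, this is the same kind of change as the one from compound 1 to compound 2, not the same: there the place was a saturated chain carbon bound to two saturated chain carbons, here it is a saturated chain carbon bound to an oxygen on an aromatic ring.

Going by the values given here, for compound 4 in this assay a step of a 1.5-fold higher number from compound 3 to compound 4 (0.17 log units; within the scatter) is expected, smaller than the earlier one and upward, because a 2.4-fold higher number from compound 1 to compound 2 (0.38 log units; beyond the scatter) is the only measured example of this kind of change and its place is not the same. Compound 4 is estimated at 250 nM in this assay, expected between 120 nM and 600 nM.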

Compound 4, half-maximal effective concentration: 360 nM
For compound 4 the middle estimate is 1.4-fold (0.16 log units) below the measured one; the range from low to high includes it.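

The added methyl gives a 2.1-fold higher number from compound 3 to compound 4 (0.33 log units; beyond the scatter) in this assay. For the compounds shown here, this rests on only two pairs, and the methyl sits at a different place in each: on a saturated chain carbon bound to two saturated chain carbons in the first pair, and on a saturated chain carbon bound to an oxygen on an aromatic ring in the second, so the effects of core and place are not separated and no rule for other cores follows. Within these two pairs, the change carries from one core to the other, with steps in the same direction that cannot be told apart in size: the same change on two cores in this assay, a 2.4-fold higher number (0.38 log units; beyond the scatter) from compound 1 to compound 2 and a 2.1-fold higher number (0.33 log units; beyond the scatter) from compound 3 to compound 4, 1.1-fold (0.05 log units) apart, within the scatter of two such steps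

The compounds shown leave open whether a longer chain than ethoxy on the core of compound 3 would continue the upward step seen from methoxy to ethoxy. They also leave open how a branched chain, or a chain ending in a hydroxyl or an amine, would behave on that core.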